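The compounds below may be only part of what the source reports. "The series", "measured", "known", "first", "only" and "open" are said of these compounds alone.

Compound 1 `COc1ccc2cc(C(=O)CCN(C)C)c(=O)oc2c1` and compound 2 `COc1ccc2cc(C(=O)CCN3CCCC3)c(=O)oc2c1` share one core and differ in a single place, (pyrrolidin-1-yl in place of dimethylamino on a saturated chain carbon, two bonds along the chain from a carbonyl carbon). In an assay on cells for inhibition of Amine oxidase [flavin-containing] A (Homo sapiens), read by fluorescence, spectrophotometry and Amplex Red, with stated times of 60 min and 30 min (a lower number here means a stronger inhibitor, a higher number a weaker inhibitor), compound 1 gives 7630 nM. In this assay compound 2 gives 53100 nM, so that change made a 7.0-fold higher number from compound 1 to compound 2 (0.84 log units; beyond the scatter). Compound 3 `CN(C)CCC(=O)c1cc2cc(Br)c(O)c(Br)c2oc1=O` is built on a different core, and the difference between the two cores is not broken down here. For compound 3 only a limit of this assay is reached, > 200000 nM, and the limit of > 200000 nM in this assay, at which 1 of the 3 values shown sits, marks where that limit lies. Compound 4 `O=C(CCN1CCCC1)c1cc2cc(Br)c(O)c(Br)c2oc1=O` has not yet been measured; it stands to compound 3 exactly as compound 2 stands to compound 1, the same change in the same place, (pyrrolidin-1-yl in place of dimethylamino on a saturated chain carbon, two bonds along the chain from a carbonyl carbon). Among the measured compounds shown here, since the one measured instance of this change gave a higher number and compound 3 already sits at the limit, the number for compound 4 is expected to stay at or past that limit, an expected step that the limit leaves unreadable from compound 3 to compound 4 that rests on a 7.0-fold higher number from compound 1 to compound 2 (0.84 log units; beyond the scatter). Compound 4 is therefore estimated at 400000 nM in this assay, with an expected range from 200000 nM to 2000000 nM.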

Compound 4, half-maximal inhibitory concentration: 155000 nM
The estimate for compound 4 lay 2.6-fold (0.41 log units) above the measured number; measured number outside the range, below it.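

On the core of compound 3, the change from dimethylamino to pyrrolidin-1-yl gave an at least 1.2-fold lower number from compound 3 to compound 4 (0.11 log units; that floor lies within the scatter) in this assay, so the rise in the number seen on the core of compound 1 did not carry over, and the two steps differ by more than repeated measurements would explain: the same change on two cores in this assay, a 7.0-fold higher number (0.84 log units; beyond the scatter) from compound 1 to compound 2 and an at least 1.2-fold lower number (0.11 log units; that floor lies within the scatter) from compound 3 to compound 4, at least 8.9-fold (0.95 log units) apart, beyond the scatter of two such steps. For compound 3 the value of > 200000 nM is a limit of the assay, and so the second step has only a floor, whose size lies within the scatter. The result therefore shows that the step on one core could not be carried to the other in this pair, but it does not fix how large the second step is, and one pair per core shows no rule for the series.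

Which part of the difference between the two cores goes with this contrast remains open. Going by these compounds, it is also open how piperidin-1-yl, morpholin-4-yl or a longer chain to the amine would behave on either core.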